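The source may report more compounds than this note shows. Statements on the series, on what has been measured and on what is new or still open speak of the compounds shown alone.

Measured compounds in a functional assay on PC-3 cells (Homo sapiens) for inhibition; on this read-out higher numbers stand for weaker inhibition and lower numbers for stronger inhibition:
compound 1 `Cc1c(C(=O)N/N=C\c2cccc(F)c2O)oc2cccc(O)c12`, 12700 nM
compound 2 `Cc1c(C(=O)N/N=C\c2cccc(O)c2)oc2cccc(O)c12`, 17600 nM
compound 3 `Cc1c(C(=O)N/N=C\c2ccc(O)cc2O)oc2cccc(O)c12`, 14800 nM

Compound 3 sits between the other two, with compound 1 nearest and compound 2 furthest, and all three lie within the scatter of one another. The next compound, compound 4 `COc1cccc(/C=N\NC(=O)c2oc3cccc(O)c3c2C)c1`, is obtained from compound 3 by the change (3-methoxyphenyl in place of 2,4-dihydroxyphenyl on a carbon with a double bond to nitrogen). For the measured compounds named here, the steps that bear on this are the aryl swaps already measured: a 1.2-fold lower number from compound 2 to compound 3 (0.08 log units; within the scatter) and a 1.2-fold higher number from compound 1 to compound 3 (0.07 log units; within the scatter), neither of which leaves the scatter. Compound 2 carries the 3-hydroxyphenyl that is closest to the incoming 3-methoxyphenyl, but no direct comparison of hydroxy against methoxy exists in this set. The expectation is therefore a step of a 1.1-fold higher number from compound 3 to compound 4 (0.06 log units; within the scatter), not beyond the scatter. Compound 4 is estimated at 17000 nM, range 8000 nM to 40000 nM.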

Compound 4, half-maximal inhibitory concentration: >= 40000 nM
Compound 4: no number, only a limit; the forecaster's own chance of this, stated with the estimate: 15%; middle value at least 2.3-fold (0.37 log units) away from the limit.
By their numbers in this assay, from the lowest: compounds 1, 3 and 2 (each within the scatter of the next). At a limit, above all of these: compound 4.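

In this assay compound 4 stands at a limit, not a number: the limit of >= 40000 nM in this assay, at which 1 of the 4 values shown sits.

Methyl in place of hydrogen on the aromatic oxygen gives an at least 2.2-fold higher number from compound 2 to compound 4 (0.35 log units; beyond the scatter), so this position, unmoved by the earlier aryl swaps, does respond to this single change. The wider swaps give an at least 2.7-fold higher number from compound 3 to compound 4 (0.43 log units; beyond the scatter) and an at least 3.1-fold higher number from compound 1 to compound 4 (0.49 log units; beyond the scatter), with the entering 3-methoxyphenyl counting 0 hydrogen-bond donors against 2 for the departing 2,4-dihydroxyphenyl.

Going by these compounds, the full size of these steps stays open at a limit. Also open, on these data alone, is how an amine or a carboxylic acid on this aryl ring, or ethyl in place of the methyl on the oxygen, would read.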